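The compounds below may be only part of what the source reports. "The series", "measured", "known", "first", "only" and "open" are said of these compounds alone.

Of the compounds shown here, three sharing one core have been tested in a functional assay on CCRF-CEM cells (Homo sapiens) for cytotoxicity, read by sulforhodamine B assay, with a stated time of 72 h; on this read-out lower numbers stand for stronger inhibition and higher numbers for weaker inhibition. Compound 1, `OCC#CCSc1cnc2ccccc2c1Cl`, carries a chloro group on the shared core and gives 4.1 ug/mL. Among the three numbers this places compound 1 second highest: its nearest neighbour is compound 2, `C[Se]c1c(SCC#CCO)cnc2ccccc12`, which gives 2.1 ug/mL, while compound 3, `CSc1c(SCC#CCO)cnc2ccccc12`, stands furthest away with 13.9 ug/mL. Two of the steps between these compounds have been worked out. The change a 2.0-fold lower number from compound 1 to compound 2 (0.29 log units; within the scatter). The change a 3.4-fold higher number from compound 1 to compound 3 (0.53 log units; beyond the scatter), and a 6.6-fold higher number from compound 2 to compound 3 (0.82 log units; beyond the scatter).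

Compound 4, `C#CC[Se]c1c(SCC#CCO)cnc2ccccc12`, has not yet been measured. Compared with compound 1 it shows (a group of 4 heavy atoms (3 carbon, 1 selenium; no ring) in place of one chlorine atom, on an aromatic carbon). Going by the values given here, the step that bears most directly on this change is the one from compound 1 to compound 2, where a group containing selenium also replaced the chlorine and the number moved only within the scatter. Among the compounds with values here, the added carbons with the triple bond have no counterpart among the measured compounds, so nothing shows whether they push the number up or down. On this basis the expected step is a 1.4-fold lower number from compound 1 to compound 4 (0.14 log units; within the scatter), which is not expected to exceed the scatter. Compound 4 is therefore estimated to give 3 ug/mL, with a range from 1.2 ug/mL to 8 ug/mL.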

Compound 4, concentration for 50% inhibition: 1.9 ug/mL
For compound 4 the middle estimate is 1.6-fold (0.20 log units) above the measured one; the measured number falls inside the stated range.
By their numbers in this assay, from the lowest: compounds 4, 2 and 1 (each within the scatter of the next, the first and the last beyond it); then compound 3.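

In this assay, a 1.1-fold lower number from compound 2 to compound 4 (0.04 log units; within the scatter) shows that ethynyl in place of hydrogen on the saturated chain carbon bound to selenium leaves the number within the scatter, so at this position a larger selenium group with a triple bond gives much the same result as the smaller one. The replacement of chloro by this larger group gives a 2.2-fold lower number from compound 1 to compound 4 (0.33 log units; beyond the scatter), the first step away from chloro towards a lower number that lies beyond the scatter, although its size stays modest. With a 7.3-fold lower number from compound 3 to compound 4 (0.86 log units; beyond the scatter) set beside a 6.6-fold higher number from compound 2 to compound 3 (0.82 log units; beyond the scatter), both selenium compounds now have numbers well below that of the methylsulfanyl compound, and no compound shown goes against this.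

As far as these compounds go, it remains open whether a saturated propyl chain on selenium would give a similar number, and whether the chain with the triple bond would behave the same way on sulfur. From the compounds shown here alone, the effect of an amine or a carboxylic acid at this position also remains open. Nothing available here explains why any of these steps has the size it has.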